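Swapping the aryl group on the amine of compound 1

A few compounds are considered here, and "the series" means these few. Any claim that something is new, unique, unknown or untested is made for them only; others in the source may bear on it.

Measured compounds:
compound 1, `O=C1C(Nc2ccc(I)cc2)=CC(=O)c2c1nc1n2[C@H]2OC[C@@H](O)[C@H]2OC1`, 3890 nM
compound 2, `CCOc1ccc(NC2=CC(=O)c3nc4n(c3C2=O)[C@H]2OC[C@@H](O)[C@H]2OC4)cc1`, 1430 nM
compound 3, `Cc1ccc(NC2=CC(=O)c3nc4n(c3C2=O)[C@H]2OC[C@@H](O)[C@H]2OC4)cc1C`, 2080 nM

In a functional assay on MCF7 cells (Homo sapiens) for inhibition, read by sulforhodamine B assay (on this read-out higher numbers stand for weaker inhibition and lower numbers for stronger inhibition), compound 1 gives the highest number of the three; compound 2 lies beyond the scatter below it, while compound 3 lies within the scatter of compound 1. Among the measured compounds shown here, the only step between neighbours, a 1.5-fold higher number from compound 2 to compound 3 (0.16 log units; within the scatter), changes the aryl group on the amine nitrogen without leaving the scatter.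

Compound 4, `COc1cccc(NC2=CC(=O)c3c(nc4n3[C@H]3OC[C@@H](O)[C@H]3OC4)C2=O)c1`, is not yet measured. It differs from compound 1 as follows: 3-methoxyphenyl in place of 4-iodophenyl on an amine nitrogen. For the measured compounds named here, no measured step swaps an iodo group for a methoxy group, so the expectation rests on the gap from compound 1 to compound 2, which is beyond the scatter, and on the unchanged reading from compound 2 to compound 3. A move towards a lower number is therefore expected, but a small one; the step of a 1.8-fold lower number from compound 1 to compound 4 (0.25 log units; within the scatter) is the estimate. Compound 4 is expected to give 2200 nM in this assay, within 900 nM to 5500 nM.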

Compound 4, half-maximal inhibitory concentration: 3830 nM
Compound 4: the middle estimate sits 1.7-fold (0.24 log units) below what was measured; measured number inside the range.
By their numbers in this assay, from the lowest: compounds 2, 3, 4 and 1 (each within the scatter of the next, the first and the last beyond it).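

In this assay, the exchange of 4-iodophenyl for 3-methoxyphenyl on the amine nitrogen leaves the reading in place (a 1.0-fold lower number from compound 1 to compound 4 (0.01 log units; within the scatter)), and this is the first step shown from compound 1 that exchanges the iodo group for an oxygen-bearing group. The gap beyond the scatter that separates compound 2 from compound 1 therefore does not appear with every aryl group carrying an alkoxy group, and the hydrogen-bond acceptor counted in 3-methoxyphenyl comes with no readable shift at this position. No measurement at hand gives a reason for this reading.

The step changes both the group and its number in the name, so the two changes cannot be read apart; a 4-methoxyphenyl or 3-iodophenyl group would separate them. Also open, from the compounds shown here alone, is how an unsubstituted phenyl group, or an aryl group bearing an amine or a carboxylic acid, would read here.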